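The compounds below may be only part of what the source reports. "The series", "measured", "known", "first", "only" and "open" are said of these compounds alone.

Within the data shown here, compound 1 `CCCc1nc(-c2ccccc2)c(CNCCN2CCN(c3ccc(C)cc3)CC2)o1` is one of two compounds measured in an assay on HEK293 cells for inhibition of Voltage-dependent T-type calcium channel subunit alpha-1G (Homo sapiens), read by fluorescence, tested at 10 uM; a lower number here means less inhibition, a higher number more inhibition at the concentration tested (going by the name of the read-out). Compound 1 gives 48.1%, and compound 2 `CCCc1nc(-c2ccccc2)c(CNCCCN2CCN(c3cccc(C)c3C)CC2)o1` gives 55.2%; the two values lie within the usual scatter of each other, so neither stands apart. Compound 3 `CCCc1nc(-c2ccccc2)c(CNCCN2CCN(c3cccc(Cl)c3)CC2)o1` has not yet been measured. It differs from compound 1 in one place: 3-chlorophenyl in place of 4-methylphenyl on an amine nitrogen in a ring. Among the measured compounds shown here, with no measured step of this kind to lean on, the step of a number 1.9 percentage points higher from compound 1 to compound 3 (within the scatter) is expected to stay within the scatter, in no particular direction. Compound 3 is therefore expected to give about 50%, with a range from 30% to 70%.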

Compound 3, a percentage reported as inhibition, at one concentration (the size of the read-out at that concentration, not a potency): 51.2%
Compound 3: middle estimate off by 1.2 percentage points, on the low side, and the stated range covers the measured number.
By their numbers in this assay, from the lowest: compounds 1, 3 and 2 (each within the scatter of the next).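

Putting 3-chlorophenyl in place of 4-methylphenyl on an amine nitrogen in a ring gives a number 3.1 percentage points higher from compound 1 to compound 3 (within the scatter) in this assay. Among these compounds, this is the first step read at this position, and with it the two compounds cannot be told apart, although the group differs both in its substituent and in where that substituent sits. Nothing shown gives a reason for this result. The compounds shown leave open how 4-chlorophenyl or 3-methylphenyl would read, which would separate those two differences. They also leave open whether a carboxylic acid or an amine on this phenyl ring would stand apart in this assay.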